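A few compounds are considered here, and "the series" means these few. Any claim that something is new, unique, unknown or untested is made for them only; others in the source may bear on it.

The compounds here were tested in a functional assay on MCF7 cells (Homo sapiens) for inhibition, read by MTT assay, with a stated time of 72 h; a higher number here means a weaker inhibitor, a lower number a stronger inhibitor. Compound 1, `COc1ccccc1/C=C/C=N/N1C(=S)NC2C1N(C)C(=O)N2c1ccccc1`, gives 260 nM. Compound 2, `CCN1C(=O)N(c2ccccc2)C2NC(=S)N(/N=C/C=C/c3ccccc3OC)C21`, gives 79100 nM in this assay. The step between them, a 300-fold higher number from compound 1 to compound 2 (2.48 log units; beyond the scatter), comes with one small change: methyl in place of hydrogen on a saturated chain carbon bound to an amide-type nitrogen in a ring.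

Compound 3, `CCN1C(=O)N(CC)C2C1N=C(SC)N2/N=C/C=C/c1ccccc1[N+](=O)[O-]`, gives 66700 nM in this assay, so it sits close to compound 2 and far from compound 1. Compound 3 and compound 1 differ in more than one place, and the difference between the two cores is not broken down here.

Compound 4, `CCSC1=NC2C(N(CC)C(=O)N2CC)N1/N=C/C=C/c1ccccc1[N+](=O)[O-]`, has not yet been measured. It differs from compound 3 by methyl in place of hydrogen on a saturated chain carbon bound to a sulfur. For the measured compounds named here, this is the same kind of change as the one from compound 1 to compound 2, but the place is not the same: there the methyl entered on a saturated chain carbon bound to an amide-type nitrogen in a ring, here on a saturated chain carbon bound to a sulfur. Because compound 3 already gives 66700 nM, and because the earlier step of a 300-fold higher number from compound 1 to compound 2 (2.48 log units; beyond the scatter) was made at a different place, only a modest step of a 1.3-fold higher number from compound 3 to compound 4 (0.13 log units; within the scatter) is expected. Compound 4 is therefore estimated at 90000 nM, roughly between 30000 nM and 300000 nM.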

Compound 4, half-maximal inhibitory concentration: 30700 nM
Compound 4: the middle estimate sits 2.9-fold (0.47 log units) above what was measured, within the range that was stated.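

On the core of compound 3, the methyl that turns methylsulfanyl into ethylsulfanyl gives a 2.2-fold lower number from compound 3 to compound 4 (0.34 log units; beyond the scatter), a small step in the opposite direction from the large rise seen earlier on the core of compound 1. Set side by side in this assay, the two steps clearly disagree: the same change on two cores in this assay, a 300-fold higher number (2.48 log units; beyond the scatter) from compound 1 to compound 2 and a 2.2-fold lower number (0.34 log units; beyond the scatter) from compound 3 to compound 4, 660-fold (2.82 log units) apart, beyond the scatter of two such steps

This shows that the effect of adding this methyl cannot simply be carried from one core to another in this series, but it does not show why, and two pairs give no rule for other cores, especially as the methyl enters at a different place in each pair.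

The compounds shown leave open how a longer chain, such as propyl, or an amine-bearing chain would behave on the sulfur. They also leave open whether the step from compound 3 to compound 4 would recur in another pair with the same methyl-to-ethyl change on a sulfur.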